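Swapping a cyclohexylmethyl for an ethoxy on the carbonyl

The compounds below may be only part of what the source reports. "The series", "measured", "known", "first", "only" and "open" are said of these compounds alone.

Measured compounds:
compound 1, `Cc1cc(C(=O)Nc2ccccn2)nn1Cc1cc(Cl)ccc1OCc1ccccc1`: > 3.7
compound 2, `Cc1cc(NC(=O)CC2CCCCC2)nn1Cc1cc(Cl)ccc1OCc1ccccc1`: 3.2

Of the compounds shown here, two sharing one core have been measured in a physicochemical assay for lipophilicity, at pH 7.4; a higher number here means a more lipophilic compound, a lower number a more polar compound. Compound 1 reaches only > 3.7, which is a limit of the assay rather than a number. Among the compounds with values here, compound 2 gives 3.2 in this assay, the only actual number here, and it sits at or beyond the limit of > 3.7 in this assay, at which 1 of the 2 values shown sits, by a number at least 0.50 log units lower from compound 1 to compound 2 (beyond the scatter).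

Compound 3, `CCOC(=O)Nc1cc(C)n(Cc2cc(Cl)ccc2OCc2ccccc2)n1`, has not yet been measured. It differs from compound 2 by ethoxy in place of cyclohexylmethyl on a carbonyl carbon. Within the data shown here, no measured step covers this exact exchange; the one known step, from compound 1 to compound 2, involves a different pair of groups. Going by the size of what leaves and what enters, a drop in this assay is expected, by a number 1.50 log units lower from compound 2 to compound 3 (beyond the scatter). Compound 3 is therefore estimated at 1.7, within a range of 1 to 2.4.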

Compound 3, distribution coefficient: > 3.7
Compound 3: a limit, no number; the forecaster's own chance of this, stated with the estimate: 5%; middle value at least 2.00 log units away from the limit.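

In this assay, putting ethoxy in place of cyclohexylmethyl on the carbonyl carbon gives a number at least 0.50 log units higher from compound 2 to compound 3 (beyond the scatter). For this one pair, then, a smaller group without a ring and with a hydrogen-bond acceptor does not bring the reading down, which compound 1 and compound 2 alone could not show. The reading of compound 3 is a limit and not a number, and compound 1 shares that limit: the limit of > 3.7 in this assay, at which 2 of the 3 values shown sit.

On these data alone, how far compound 3 lies past that limit stays unknown, and the step between compound 1 and compound 3 cannot be read. Also open, as far as these compounds go, is whether an amine such as dimethylamino, or a longer chain such as butoxy, on the same carbonyl carbon would give a true number in this assay.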